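A Methyl Group Added to Compound 3

The source may hold more compounds than are shown below. What is called first, only, known or untested is meant among the compounds shown, and "the series" means these compounds.

Measured compounds:
compound 1, `C/C(=C\c1cc(-c2ccccc2)co1)C(N)=O` — in a functional assay on A549 cells (Homo sapiens) for cytotoxicity, read by CCK-8 assay, with a stated time of 24 h (a lower number here means a stronger inhibitor, a higher number a weaker inhibitor), compound 1 gives > 50000 nM, a limit of the assay
compound 2, `C/C(=C\c1cc(-c2ccc(F)cc2)co1)C(N)=O` — compound 2 gives 14900 nM
compound 3, `C/C(=C\c1cc(-c2cccnc2)co1)C(N)=O` — compound 3 gives 6620 nM

Compound 3 has the lowest of the two numbers shown; compound 2 gives a higher number, beyond the scatter, and compound 1 sits at the limit of > 50000 nM in this assay, at which 1 of the 3 values shown sits. Compound 4, `C/C(=C\c1cc(-c2ccc(C)nc2)co1)C(N)=O`, differs from compound 3 by methyl in place of hydrogen on an aromatic carbon. Among the measured compounds shown here, the only measured step is an at least 3.3-fold lower number from compound 1 to compound 2 (0.52 log units; beyond the scatter), which concerns fluoro on a different ring and bears only loosely on a methyl change. For the measured compounds named here, no measured step tests a methyl, so no shift beyond the scatter is expected. Compound 4 is therefore estimated at 6000 nM, between 2000 nM and 18000 nM, a step of a 1.1-fold lower number from compound 3 to compound 4 (0.04 log units; within the scatter) expected to stay within the scatter.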

Compound 4, half-maximal inhibitory concentration: > 50000 nM
Compound 4: no number, only a limit (the forecaster's own chance of this, stated with the estimate: 3%); at least 8.3-fold (0.92 log units) between middle value and limit.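

In this assay, the first change shown on the six-membered aromatic ring with 1 nitrogen is not neutral: methyl in place of hydrogen, next to the ring nitrogen and para to a large group, gives an at least 7.5-fold higher number from compound 3 to compound 4 (0.87 log units; beyond the scatter). Compound 4 gives > 50000 nM, a limit of the assay, and it shares that limit with compound 1: the limit of > 50000 nM in this assay, at which 2 of the 4 values shown sit.

Going by these compounds, the true size of the step therefore stays unknown. Also open, on these data alone, is whether an amine, a methoxy group or a chlorine at this place would keep the number of compound 3 or lose it as methyl does.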